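Compound 3 to compound 4: swapping the ether chain

This account rests on a few compounds, and the source may have more. Where it says the series, first, only, none or still open, it means among the compounds named here.

In an ADME assay on S9 fraction from liver (Homo sapiens) for metabolic stability, read by LC-MS, using NADPH, with stated times of 5 min and 60 min, tested at 5 uM (on this read-out higher numbers stand for a more stable compound and lower numbers for a less stable compound), compound 3 `COc1cc(C2CN(C(=O)c3cc(OC[C@@H](O)CO)ccn3)C2)ccc1OCc1ccc(C2CC2)cc1` gives 63%. Compound 2 `COc1cc(C2CN(C(=O)c3cc(OC[C@H](O)CO)ccn3)C2)ccc1OCc1ccc(C2CC2)cc1` gives 64%, which is level with compound 3 within the scatter. Compound 1 `COc1ccc(COc2ccc(C3CN(C(=O)c4cc(OCCO)ccn4)C3)cc2OC)cc1` gives 38%, a gap to compound 3 that lies beyond the scatter.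

Compound 4 `COc1cc(C2CN(C(=O)c3cc(OCCCC(C)(C)C(=O)O)ccn3)C2)ccc1OCc1ccc(C2CC2)cc1` keeps the shared core of compound 3 and changes one group: 3-carboxy-3-methylbutyl in place of 1,2-dihydroxyethyl on a saturated chain carbon bound to an oxygen on an aromatic ring. The 2,3-dihydroxypropoxy chain gives way to (4-carboxy-4-methylpentyl)oxy.

Within the data shown here, the only measured step between two compounds that differ in one place is a number 1 percentage points lower from compound 2 to compound 3 (within the scatter). It concerns (the fact that compounds 2 and 3 differ only in the configuration as drawn), so it bears on this exchange only indirectly: it shows that the two drawn configurations of the chain read alike, and it does not test a different chain. Among the measured compounds shown here, compound 1 differs from compound 3 in more than one place and gives no clean step. For the measured compounds named here, no measured compound carries the carboxy chain.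

Going by the values given here, with no measured step to point either way, no step beyond the scatter is expected in this assay, and the uncertainty is wide. The expected change is a number 2 percentage points higher from compound 3 to compound 4 (within the scatter).

Compound 4 is estimated at 65%, with an expected range of 43% to 85%.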

Compound 4, percent of the compound remaining: 81%
Estimate against measurement, compound 4: 16 percentage points below, within the range that was stated.
By their numbers in this assay, from the lowest: compound 1; then compounds 3 and 2 (each within the scatter of the next); then compound 4.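

In this assay, the position on a saturated chain carbon bound to an oxygen on an aromatic ring proves sensitive to the group it carries: a number 18 percentage points higher from compound 3 to compound 4 (beyond the scatter), and a number 17 percentage points higher from compound 2 to compound 4 (beyond the scatter). The earlier compounds shown here varied only the drawn configuration of the 1,2-dihydroxyethyl group, with no step beyond the scatter, so these two steps amount to one exchange seen from either configuration: the fact that compounds 2 and 3 differ only in the configuration as drawn. The exchange for 3-carboxy-3-methylbutyl alters chain length, end group and branching together, so the higher number belongs to the exchange as a whole and not to any one of these features.

The compounds shown do not separate the carboxylic acid from the longer chain or from the branching methyl groups, and a straight chain ending in a carboxylic acid, or a chain of the same length ending in an alcohol or an amine, would divide these contributions. Going by these compounds, whether the same exchange holds on the core of compound 1, with its different benzyl ether, also remains open.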